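This account rests on a few compounds, and the source may have more. Where it says the series, first, only, none or still open, it means among the compounds named here.

Measured so far in a functional assay on CHO cells for agonist activity at Free fatty acid receptor 1 (Homo sapiens), read by a luciferase reporter; on this read-out higher numbers stand for larger maximal responses and lower numbers for smaller maximal responses:
- compound 1 `Cc1nc(-c2ccc(C(F)(F)F)cc2)sc1CNc1ccc(CCCC(=O)O)cc1`: 44%
- compound 2 `NC(=O)CCc1ccc(NCc2cccc(Oc3ccccc3)c2)cc1`: 68%
- compound 3 `CNC(=O)CCc1ccc(NCc2cccc(Oc3ccccc3)c2)cc1`: 67%

Compound 1 has the lowest of the three numbers in this assay; the gap to compound 3 and to compound 2 lies beyond the scatter in both cases. Within the data shown here, the one step measured, a number 1 percentage points lower from compound 2 to compound 3 (within the scatter), lies within the scatter and concerns only the substitution on an amide-type nitrogen, on a core different from that of compound 1.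

Compound 4 `Cc1nc(-c2ccc(C(F)(F)F)cc2)sc1CNc1ccc([C@H]2C[C@@H]2C(=O)NC2CCNC2)cc1` differs from compound 1 in one place: 2-((pyrrolidin-3-yl)carbamoyl)cyclopropyl in place of 3-carboxypropyl on an aromatic carbon. Among the measured compounds shown here, no measured pair covers an exchange of this kind, so the step of a number 1 percentage points lower from compound 2 to compound 3 (within the scatter) bears on it only in that an amide-type nitrogen carrying a substituent gave a number close to that of the unsubstituted amide. Compounds 2 and 3, which carry a carboxamide-type terminus rather than a carboxylic acid, both give numbers higher than compound 1, but on another core, so this is weak support.

For compound 4 a moderate rise is expected, a number 11 percentage points higher from compound 1 to compound 4 (beyond the scatter), with wide uncertainty; the estimate is 55%, between 30% and 80%.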

Compound 4, largest response reached (reported as percent of maximum), in percent of the reference or control that the assay uses: 52%
For compound 4 the middle estimate is 3 percentage points above the measured one, within the range that was stated.
By their numbers in this assay, from the lowest: compounds 1 and 4 (each within the scatter of the next); then compounds 3 and 2 (each within the scatter of the next).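

On the shared core, at the aromatic carbon para to a large group, putting 2-((pyrrolidin-3-yl)carbamoyl)cyclopropyl in place of 3-carboxypropyl gives, in this assay, a number 8 percentage points higher from compound 1 to compound 4 (within the scatter). The position therefore accepts a group with 11 heavy atoms and two non-aromatic rings in place of a 6-atom open chain, and compound 4 still gives a measurable maximal response without a carboxylic acid. No measurement at hand accounts for this result.

The exchange alters the linker and the terminal group together, so their separate contributions cannot be told apart. Open questions on this core are what a cyclopropyl carrying a carboxylic acid would give, what a plain carboxamide on the 3-carbon chain would give, and what the opposite cyclopropyl stereochemistry would give.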